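The compounds below may be only part of what the source reports. "The series", "measured", "known", "first", "only" and "open" are said of these compounds alone.

Working notes on the series. For the measured compounds named here, compound 1 `OC(CCn1nc2c(Br)c(Br)c(Br)c(Br)c2n1)c1ccc(Br)cc1` gives 59% in a functional assay on MCF7 cells (Homo sapiens) for antiproliferative activity, read by MTT assay, with a stated time of 24 h, tested at 25 uM (a higher number here means a weaker effect of the compound at the concentration tested, a lower number a stronger effect), the lowest of the three numbers so far. Going by the values given here, compound 2 `C[C@@H](O)CCn1nc2c(Br)c(Br)c(Br)c(Br)c2n1` gives 105% in this assay, and compound 3 `OC(CCn1nc2c(Br)c(Br)c(Br)c(Br)c2n1)c1ccc(Cl)cc1` gives 96% in this assay; the single recorded step, a number 37 percentage points higher from compound 1 to compound 3 (beyond the scatter), is large. Compound 4 `OC(CCn1nc2c(Br)c(Br)c(Br)c(Br)c2n1)c1cccc(Br)c1` is not yet measured and differs from compound 1 by 3-bromophenyl in place of 4-bromophenyl on a saturated chain carbon bound to an oxygen on a saturated carbon and a saturated chain carbon. Among the compounds with values here, no measured step covers a change of this kind; the step from compound 1 to compound 3 bears on it only in showing that the number moves readily when the group on the chain carbon is altered. For compound 4 the step expected in this assay is a number 13 percentage points higher from compound 1 to compound 4 (beyond the scatter), with either direction open. For compound 4 the estimate in this assay is 72%, within 45% to 100%.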

Compound 4, a percentage reported as activity, at one concentration (the size of the read-out at that concentration, not a potency): 52%
Beside the measured number, compound 4's estimate is 20 percentage points above it; the range from low to high includes it.
By their numbers in this assay, from the lowest: compounds 4 and 1 (each within the scatter of the next); then compounds 3 and 2 (each within the scatter of the next).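

In this assay, 3-bromophenyl in place of 4-bromophenyl gives a number 7 percentage points lower from compound 1 to compound 4 (within the scatter) and so does not separate these two placements of the bromine on the phenyl ring. 3-Bromophenyl in place of 4-chlorophenyl gives a number 44 percentage points lower from compound 3 to compound 4 (beyond the scatter) and thus shows a second bromophenyl compound standing clear of the chlorophenyl compound 3. Nothing available explains either result. Still open, from the compounds shown here alone, is whether a 3-chlorophenyl, a 2-bromophenyl or an unsubstituted phenyl on this chain carbon would group with compound 1 and compound 4 or with compound 3.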